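The compounds below may be only part of what the source reports. "The series", "measured", "known", "first", "only" and "open" are said of these compounds alone.

Of the compounds shown here, three built on a shared core have been tested in a functional assay on HL-60 cells (Homo sapiens) for antiproliferative activity, read by MTT assay, with a stated time of 48 h; a higher number here means a weaker inhibitor, a lower number a stronger inhibitor. Compound 1 `CNC1=C(Cl)C(=O)c2cccnc2C1=O` gives 4300 nM in this assay. Compound 2 `NC1=C(Cl)C(=O)c2ncccc2C1=O` gives 3260 nM, and compound 3 `CSC1=C(N)C(=O)c2cccnc2C1=O` gives 7640 nM. The numbers of compound 1 and compound 2 lie within the scatter of each other, as do those of compound 1 and compound 3. How the core of compound 1 differs from that of compound 2 is not broken down here. From compound 2 to compound 3 the change is methylsulfanyl in place of chloro on a double-bonded ring carbon and it made a step of a 2.3-fold higher number from compound 2 to compound 3 (0.37 log units; beyond the scatter).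

Compound 4 `CNC1=C(SC)C(=O)c2cccnc2C1=O` has not yet been measured. It arises from compound 1 by the same kind of change, (methylsulfanyl in place of chloro on a double-bonded ring carbon); the places differ in that the ring atom next to the changed carbon bears a methylamino group in compound 1 rather than an amino group. The step from compound 1 to compound 4 is expected to be of a similar size, a 2.2-fold higher number from compound 1 to compound 4 (0.34 log units; beyond the scatter), because the same kind of change gave a 2.3-fold higher number from compound 2 to compound 3 (0.37 log units; beyond the scatter). Compound 4 is therefore estimated at 9500 nM, with a range from 4000 nM to 22000 nM.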

Compound 4, half-maximal inhibitory concentration: 7920 nM
Beside the measured number, compound 4's estimate is 1.2-fold (0.08 log units) above it; the measured number falls inside the stated range.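

In this assay, methylsulfanyl in place of chloro on a double-bonded ring carbon gives a 1.8-fold higher number from compound 1 to compound 4 (0.27 log units; within the scatter). This step lies within the scatter and the earlier one beyond it, yet the two steps themselves do not differ by more than the scatter, so the change carries over from one core to the other at a comparable size: the same change on two cores in this assay, a 2.3-fold higher number (0.37 log units; beyond the scatter) from compound 2 to compound 3 and a 1.8-fold higher number (0.27 log units; within the scatter) from compound 1 to compound 4, 1.3-fold (0.10 log units) apart, within the scatter of two such steps. Among these compounds, this rests on only two steps in a single assay, and it does not show that the change would keep this size on other cores, nor does it explain why either step has the size it has.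

The compounds shown leave open how other groups would compare in place of chloro or methylsulfanyl, such as methoxy, a longer alkylsulfanyl chain or a nitrile. They also leave open whether the step would hold with a larger amine, such as dimethylamino or morpholine, in place of the amino or methylamino group.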